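The source may hold more compounds than are shown below. What is called first, only, known or untested is meant among the compounds shown, and "the series" means these compounds.

Measured in a functional assay on Vero cells (Chlorocebus sabaeus) for cytotoxicity; on this read-out lower numbers stand for higher toxicity in this test and higher numbers for lower toxicity in this test:
Compound 1 `O=c1ccn(COC(CO)CO)c(=O)[nH]1`: > 462000 nM
Compound 2 `Cc1cn(COC(CO)CO)c(=O)[nH]c1=O`: > 434000 nM

Both entries are limits and not numbers. Compound 2 stands at > 434000 nM, which is a limit. Compound 3 `O=c1[nH]c(=O)n(COC(CO)CO)cc1CO` is the next step: hydroxy in place of hydrogen on a saturated chain carbon bound to an aromatic carbon, that is, methyl to hydroxymethyl. For the measured compounds named here, the only measured step that bears on it is a step that the two limits leave unreadable from compound 1 to compound 2, so no size can be carried over. No step beyond the scatter is expected in this assay, and the expected outcome is an at least 1.0-fold lower number from compound 2 to compound 3 (0.02 log units; that floor lies within the scatter). For compound 3 the estimate is 406000 nM, with an expected range from 200000 nM to 600000 nM.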

Compound 3, half-maximal cytotoxic concentration: > 406000 nM
Compound 3 was reported as a limit; the forecaster's own chance of this, stated with the estimate: 85%; the middle value lies on the limit itself.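

For the compounds shown here, compound 1, compound 2 and compound 3 are all reported as limits in this assay, so no step among them can be read. The compounds shown leave open at what concentration, if any, this series becomes cytotoxic.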